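Imidazolylmethyl in place of pyridyl on two naphthalene cores

A few compounds are considered here, and "the series" means these few. Any claim that something is new, unique, unknown or untested is made for them only; others in the source may bear on it.

Compound 1 `Fc1ccc(-c2ccc3c(-c4ccncc4)cccc3c2)cc1` gives 28% in an assay for inhibition of steroid 17-alpha-hydroxylase/17,20 lyase (Homo sapiens), tested at 2 uM; on this read-out higher numbers stand for a stronger effect at the one concentration tested and lower numbers for a weaker effect. Compound 2 `Fc1ccc(-c2ccc3c(Cn4ccnc4)cccc3c2)cc1` gives 19% in this assay; the change (1H-imidazol-1-yl)methyl in place of pyridin-4-yl on an aromatic carbon made a number 9 percentage points lower from compound 1 to compound 2 (within the scatter). Compound 3 `COc1ccc2cc(-c3cccc(-c4ccncc4)c3)ccc2c1` gives 23% in this assay; the difference between the core of compound 3 and the core of compound 1 is not broken down here. Compound 4 `COc1ccc2cc(-c3cccc(Cn4ccnc4)c3)ccc2c1` carries the same kind of change, ((1H-imidazol-1-yl)methyl in place of pyridin-4-yl on an aromatic carbon); here the aromatic carbon is meta to a large group, whereas in compound 1 it is part of a fused or bridged system of two rings, ortho to a fused ring and meta to a fused ring. Compound 4 is expected to give 15%, between 4% and 28%. The expected step of a number 8 percentage points lower from compound 3 to compound 4 (within the scatter) is kept close to the earlier one. For the measured compounds named here, that earlier step, a number 9 percentage points lower from compound 1 to compound 2 (within the scatter), is the only guide, with compound 3 giving 23% as the starting point.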

Compound 4, a percentage reported as inhibition, at one concentration (the size of the read-out at that concentration, not a potency): 28%
The estimate for compound 4 lay 13 percentage points below the measured number; low and high end bracket the measured number.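

Placing (1H-imidazol-1-yl)methyl in place of pyridin-4-yl in this assay gives a number 5 percentage points higher from compound 3 to compound 4 (within the scatter), on a carbon meta to a large group. Set beside the earlier step, the change carries from one core to the other with no difference that can be told from the scatter: the same change on two cores in this assay, a number 9 percentage points lower (within the scatter) from compound 1 to compound 2 and a number 5 percentage points higher (within the scatter) from compound 3 to compound 4, 14 percentage points apart, within the scatter of two such steps. For the compounds shown here, this shows only that the change stays within the scatter on these two cores; it does not show that the change would behave alike on a further core, and a read-out at one concentration gives no potency.

Open, as far as these compounds go, is whether another group in the same place, such as an aminomethyl or a carboxylic acid, would move the read-out beyond the scatter. Also open, from the compounds shown here alone, is how the two groups compare on a third core.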